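Series notes: acetamidophenyl in place of methylethenylphenyl

This account rests on a few compounds, and the source may have more. Where it says the series, first, only, none or still open, it means among the compounds named here.

Compound 1 `C=C(C)c1ccc(N2CCN(C(=O)c3oc(C)nc3-c3ccccc3)CC2)cc1` is recorded in a functional assay on HL-60 cells (Homo sapiens) for inhibition, read by MTT assay, with a stated time of 72 h (a higher number here means a weaker inhibitor, a lower number a stronger inhibitor), as "not active" (no number reported), with no concentration behind the entry; compound 3 `CCCc1nc(-c2ccc(OC)cc2)c(C(=O)N2CCN(c3cccc(Cl)c3)CC2)o1` is likewise recorded as "not active" (no number reported). The single numerical result in this assay comes from compound 2 `COc1cc(OC)cc(N2CCN(C(=O)c3onc(C)c3-c3cccc(F)c3)CC2)c1`, which gives 152 nM. Compound 1 therefore stands among the entries without a measured number. Compound 4 `CC(=O)Nc1cccc(N2CCN(C(=O)c3oc(C)nc3-c3ccccc3)CC2)c1` is not yet measured and differs from compound 1 by 3-acetamidophenyl in place of 4-(1-methylethenyl)phenyl on an amine nitrogen in a ring. Among the measured compounds shown here, no step between measured compounds covers this change, so its size is open; a move toward measurable inhibition cannot be excluded, as compound 2 shows 152 nM, but a result again without a number is at least as likely. For compound 4 the estimated value in this assay is 6000 nM, within an expected range of 800 nM to 40000 nM.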

Compound 4, half-maximal inhibitory concentration: 329 nM
Compound 4: middle estimate off by 18-fold (1.26 log units), on the high side; measured number outside the range, below it.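

No step can be read between compound 1 and compound 4: compound 1 carries no number. Left open is what 3-acetamidophenyl in place of 4-(1-methylethenyl)phenyl alone does to inhibition, and no evidence on a cause is available.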